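Dropping the ester-bearing side chain from a resveratrol-type phenol

This account rests on a few compounds, and the source may have more. Where it says the series, first, only, none or still open, it means among the compounds named here.

The series shares one core carrying a para-hydroxyphenyl arm that is varied at the ring position next to the hydroxy group. Compound 1 `COc1ccc(/C=C/[C@@](C)(/C=C/c2ccc(O)c(/C=C/C#N)c2)CCC=C(C)C)cc1` bears a 2-cyanoethenyl group there, and in a functional assay on SEM cells (Homo sapiens) for cytotoxicity, with a stated time of 72 h (a higher number here means that more compound is needed for the effect, a lower number that less compound is needed), compound 1 gives 4540 nM. Compound 2 `CCOC(=O)/C(C)=C/c1cc(/C=C/[C@](C)(/C=C/c2ccc(OC)cc2)CCC=C(C)C)ccc1O` carries a 2-(ethoxycarbonyl)prop-1-en-1-yl group instead, and in this assay compound 2 reaches only the limit > 36600 nM. Compound 3 `COc1ccc(/C=C/[C@@](C)(/C=C/c2ccc(O)c(/C=C/C(=O)OCc3ccccc3)c2)CCC=C(C)C)cc1` carries a 2-(benzyloxycarbonyl)ethenyl group, and in this assay compound 3 likewise reaches only the limit > 36600 nM. The two ester-bearing compounds therefore both sit at the limit of > 36600 nM in this assay, at which 2 of the 3 values shown sit, so compound 3 stands at the weak end of what the numbers show: the step of an at least 8.0-fold higher number from compound 1 to compound 3 (0.90 log units; beyond the scatter) and the step of an at least 8.0-fold higher number from compound 1 to compound 2 (0.90 log units; beyond the scatter) are both at least modest, while the step that the two limits leave unreadable from compound 2 to compound 3 cannot be read.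

Compound 4 `COc1ccc(/C=C/[C@@](C)(/C=C/c2ccc(O)cc2)CCC=C(C)C)cc1` is the bare phenol, and the change is hydrogen in place of 2-(benzyloxycarbonyl)ethenyl on an aromatic carbon. Going by the values given here, no measured step removes the side chain altogether; the measured steps only swap one chain for another, so they set no direct size for this move. He expects the unsubstituted phenol to return to the measurable range, and estimates for compound 4 a value of 15000 nM, between 4000 nM and 50000 nM, which would mean a step of an at least 2.4-fold lower number from compound 3 to compound 4 (0.38 log units; beyond the scatter), though a further limit cannot be excluded.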

Compound 4, half-maximal effective concentration: > 36600 nM
Compound 4: no number, only a limit; the forecaster's own chance of this, stated with the estimate: 35%; at least 2.4-fold (0.38 log units) between middle value and limit.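

Compound 4, with hydrogen on the aromatic carbon ortho to the hydroxy group, gives no number in this assay, only a limit, and it joins compound 2 and compound 3 there: the limit of > 36600 nM in this assay, at which 3 of the 4 values shown sit. Hydrogen in place of 2-cyanoethenyl gives an at least 8.0-fold higher number from compound 1 to compound 4 (0.90 log units; beyond the scatter), the first step to show that the shared core with this position left bare does not reach a measurable value in this assay, so among the four compounds shown, only compound 1, with its 2-cyanoethenyl group, gives a number. The steps from compound 2 and from compound 3 to compound 4 cannot be read, since both ends are limits, and so the ester-bearing chains cannot be ranked against hydrogen.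

The compounds shown leave open whether the nitrile or the double bond that carries it accounts for the gap between compound 1 and compound 4, which a saturated 2-cyanoethyl chain or a nitrile set directly on the aromatic carbon would help to separate. They also leave open how a carboxylic acid or an amine at the end of the same ethenyl chain would compare with the nitrile.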